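Aryl-triazole ester series: replacing 2-methoxyphenyl with 3-fluorophenyl

The compounds below may be only part of what the source reports. "The series", "measured", "known", "first", "only" and "open" are said of these compounds alone.

Compound 1 `COc1ccccc1-n1cc(COC(=O)/C(C)=C/CC/C(C)=C/CC/C(C)=C/CC[C@@H]2[C@@]3(C)CCC(=O)C(C)(C)[C@H]3CC[C@@]2(C)O)nn1` carries a 2-methoxyphenyl on the triazole nitrogen of the shared core. In a functional assay on DU-145 cells (Homo sapiens) for antiproliferative activity, read by MTT assay, with a stated time of 48 h (a lower number here means a stronger inhibitor, a higher number a weaker inhibitor), compound 1 gives only the limit > 150000 nM, not a number. Compound 2 `C/C(=C\CC/C(C)=C/CC[C@@H]1[C@@]2(C)CCC(=O)C(C)(C)[C@H]2CC[C@@]1(C)O)CC/C=C(\C)C(=O)OCc1cn(-c2ccccc2C(F)(F)F)nn1` likewise sits at a limit, giving > 150000 nM in this assay. Among the measured compounds shown here, compound 3 `C/C(=C\CC/C(C)=C/CC[C@@H]1[C@@]2(C)CCC(=O)C(C)(C)[C@H]2CC[C@@]1(C)O)CC/C=C(\C)C(=O)OCc1cn(-c2cccc(Cl)c2)nn1` is the one member with a number, giving 103000 nM in this assay. So compound 1 stands at the top of the measured values, alongside compound 2, at the limit of > 150000 nM in this assay, at which 2 of the 3 values shown sit.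

The step from compound 1 to compound 2 is a step that the two limits leave unreadable from compound 1 to compound 2, and cannot be sized. The step from compound 1 to compound 3 is an at least 1.4-fold lower number from compound 1 to compound 3 (0.16 log units; that floor lies within the scatter), and from compound 2 to compound 3 it is an at least 1.4-fold lower number from compound 2 to compound 3 (0.16 log units; that floor lies within the scatter); both floors lie within the scatter.

Compound 4 `C/C(=C\CC/C(C)=C/CC[C@@H]1[C@@]2(C)CCC(=O)C(C)(C)[C@H]2CC[C@@]1(C)O)CC/C=C(\C)C(=O)OCc1cn(-c2cccc(F)c2)nn1` differs from compound 1 by 3-fluorophenyl in place of 2-methoxyphenyl on an aromatic nitrogen. The closest measured step is that from compound 1 to compound 3, where 3-chlorophenyl replaced 2-methoxyphenyl and the number fell at least to a readable value. A 3-fluorophenyl is expected to behave similarly, with the value of compound 4 estimated near the limit, the expected step being an at least 1.1-fold lower number from compound 1 to compound 4 (0.06 log units; that floor lies within the scatter). Compound 4 is estimated at 130000 nM, within 60000 nM to 300000 nM.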

Compound 4, half-maximal inhibitory concentration: > 150000 nM
Compound 4: a limit, no number; the forecaster's own chance of this, stated with the estimate: 55%; at least 1.1-fold (0.06 log units) between middle value and limit.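

In this assay compound 4 gives > 150000 nM, which is a limit and not a number. Compounds 3 and 4 differ only by fluoro in place of chloro on an aromatic carbon, and this exchange gives an at least 1.4-fold higher number from compound 3 to compound 4 (0.16 log units; that floor lies within the scatter), so this pair does not separate the two halogens, and 3-chlorophenyl cannot be ranked over 3-fluorophenyl. The steps to compound 4 from compound 1 and from compound 2 join two limits and cannot be read, leaving compound 3 as the only member with a number, while the limit now holds for most of the series: the limit of > 150000 nM in this assay, at which 3 of the 4 values shown sit.

Still open, going by these compounds, is whether a 3-aminophenyl or a 3-carboxyphenyl on the aromatic nitrogen would give a value clearly clear of this limit and beyond the scatter from compound 3. Also open is whether a 2-chlorophenyl or a 3-methoxyphenyl would separate the identity of the group on the phenyl ring from its place there, a question the compounds shown cannot settle since 2-methoxyphenyl and 3-chlorophenyl differ in both.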